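Hydroxyphenyl positional swaps on a shared pyridine-free core

The compounds below may be only part of what the source reports. "The series", "measured", "known", "first", "only" and "open" are said of these compounds alone.

Compound 2 `Oc1ccc(-c2cc(-c3ccccc3O)cc(-c3ccccc3O)n2)cc1` gives 6990 nM in an ADME assay on HEK293 cells (Homo sapiens) for cytotoxicity, read by CCK-8 assay, with a stated time of 4 days (on this read-out lower numbers stand for stronger inhibition and higher numbers for weaker inhibition), the highest number among the three measured compounds. Compound 1 `Oc1ccccc1-c1cc(-c2ccccc2O)nc(-c2ccccc2O)c1` gives 140 nM and compound 3 `Oc1cccc(-c2cc(-c3ccccc3O)cc(-c3ccccc3O)n2)c1` gives 730 nM. The step of a 50-fold higher number from compound 1 to compound 2 (1.70 log units; beyond the scatter) and the step of a 9.6-fold lower number from compound 2 to compound 3 (0.98 log units; beyond the scatter) both set compound 2 apart from the others beyond the scatter.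

Compound 4 `Oc1ccc(-c2cc(-c3ccc(O)cc3)nc(-c3ccccc3O)c2)cc1` is not yet measured. It differs from compound 2 by 4-hydroxyphenyl in place of 2-hydroxyphenyl on an aromatic carbon. The measured step of the same kind is a 50-fold higher number from compound 1 to compound 2 (1.70 log units; beyond the scatter), a large rise in the number. The step of a 5.2-fold higher number from compound 1 to compound 3 (0.72 log units; beyond the scatter) also raised the number when a 2-hydroxyphenyl was exchanged, though for a different partner. Both steps point toward a higher number for compound 4. Compound 4 is therefore expected to show a step of a 2.9-fold higher number from compound 2 to compound 4 (0.46 log units; beyond the scatter), smaller than the first exchange since the full size of that step is not assumed to repeat. The estimate for compound 4 is 20000 nM, with a range from 7000 nM to 60000 nM.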

Compound 4, half-maximal inhibitory concentration: 26300 nM
The estimate for compound 4 lay 1.3-fold (0.12 log units) below the measured number; low and high end bracket the measured number.
By their numbers in this assay, from the lowest: compound 1; then compound 3; then compound 2; then compound 4.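

Working notes: in this assay, exchanging 2-hydroxyphenyl for 4-hydroxyphenyl on the aromatic carbon opposite the ring nitrogen gives a 3.8-fold higher number from compound 2 to compound 4 (0.58 log units; beyond the scatter), so this exchange also raises the number at this position and in a core that already carries one 4-hydroxyphenyl. The step is modest, whereas a 50-fold higher number from compound 1 to compound 2 (1.70 log units; beyond the scatter) is large, so the same exchange differs in size between these two pairs of compounds. No supporting data bear on why the number rises at this position or why the two steps differ in size.

Still open, as far as these compounds go, is how 3-hydroxyphenyl would behave on this carbon, and what exchanging the remaining 2-hydroxyphenyl would do. The compounds shown also leave open whether the hydroxyl itself matters, which a methoxy group or an amine in its place would test.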